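Adding a 3-methoxyphenyl group to a weakly cytotoxic thiazolidinone series

This account rests on a few compounds, and the source may have more. Where it says the series, first, only, none or still open, it means among the compounds named here.

Measured compounds:
- compound 1, `Cc1ccc(-c2cc(/N=C3/NC(=O)CS3)cs2)cc1`: in a functional assay on MCF7 cells (Homo sapiens) for cytotoxicity, read by MTT assay, with a stated time of 72 h (on this read-out higher numbers stand for weaker inhibition and lower numbers for stronger inhibition), compound 1 gives > 50000 nM, a limit of the assay rather than a number.
- compound 2, `O=C1CS/C(=N\c2csc(-c3ccccc3)c2)N1`: compound 2 gives > 50000 nM, again a limit.
- compound 3, `O=C1CS/C(=N\c2csc(-c3ccc(Cl)cc3)c2)N1`: compound 3 gives > 50000 nM, again a limit.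

Compound 1 therefore stands only at the limit of the assay, and every value shown sits at that same limit (the limit of > 50000 nM in this assay, at which 3 of the 3 values shown sit). The changes among the measured compounds all concern the substituent on an aromatic carbon: a step that the two limits leave unreadable from compound 1 to compound 2, a step that the two limits leave unreadable from compound 1 to compound 3 and a step that the two limits leave unreadable from compound 2 to compound 3 are each left unreadable by the two limits.

Compound 4, `COc1cccc(N2C(=O)CS/C2=N\c2csc(-c3ccc(C)cc3)c2)c1`, differs from compound 1 at another place: 3-methoxyphenyl in place of hydrogen on an amide-type nitrogen in a ring. Within the data shown here, no measured step touches the amide-type nitrogen in the ring, so none of them bears directly on this change, and the three unreadable steps give no size to build on. The expectation rests on the fact that compound 1 gives > 50000 nM; the step from compound 1 to compound 4 is expected to be an at least 1.2-fold lower number from compound 1 to compound 4 (0.09 log units; that floor lies within the scatter). Compound 4 is thus estimated at 40000 nM, with a range from 8000 nM to 100000 nM, most likely still a limit.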

Compound 4, half-maximal inhibitory concentration: > 50000 nM
Compound 4: a limit, no number (the forecaster's own chance of this, stated with the estimate: 65%); at least 1.2-fold (0.09 log units) between middle value and limit.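

In this assay compound 4 gives > 50000 nM, a limit and not a number. Compound 1 also stands at a limit, which leaves the step between compound 1 and compound 4 unreadable. The compounds shown leave open how strongly any of them acts on these cells, and whether adding the 3-methoxyphenyl group changes that at all.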